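From a 4-chlorophenyl to a 3-hydroxyphenyl group

A few compounds are considered here, and "the series" means these few. Any claim that something is new, unique, unknown or untested is made for them only; others in the source may bear on it.

Measured in a functional assay on microsomes from liver (Rattus norvegicus, strain Wistar) for inhibition, read by spectrophotometry, with a stated time of 60 min; a higher number here means a weaker inhibitor, a lower number a stronger inhibitor:
compound 1 `COc1ccc(C(=O)ON=C2CC(c3ccc(O)c(OC)c3)N(C)C(c3ccc(O)c(OC)c3)C2)cc1` gives 40000 nM
compound 2 `COc1cc(C2CC(=NOC(=O)c3ccc(Cl)cc3)CC(c3ccc(O)c(OC)c3)N2C)ccc1O` gives 121000 nM

Of these two, compound 2 has the higher number at 121000 nM and is the weaker inhibitor, with compound 1 as its nearest neighbour. Compound 3 `COc1cc(C2CC(=NOC(=O)c3cccc(O)c3)CC(c3ccc(O)c(OC)c3)N2C)ccc1O` has not yet been measured. It has 3-hydroxyphenyl in place of 4-chlorophenyl on a carbonyl carbon. Going by the values given here, only one measured step bears on this change, and it also concerns a chloro group on an aromatic carbon: with chloro in place of methoxy, the data show a 3.0-fold higher number from compound 1 to compound 2 (0.48 log units; beyond the scatter). That step is modest but beyond the scatter. Among the compounds with values here, no measured compound carries 3-hydroxyphenyl, so the guide is indirect. A modest move toward a lower number is therefore expected, and the expected step is a 2.0-fold lower number from compound 2 to compound 3 (0.30 log units; within the scatter) in this assay. For compound 3 the estimated value is 60000 nM, with an expected range from 20000 nM to 160000 nM.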

Compound 3, half-maximal inhibitory concentration: 25300 nM
The estimate for compound 3 lay 2.4-fold (0.38 log units) above the measured number; the measured number falls inside the stated range.
By their numbers in this assay, from the lowest: compounds 3 and 1 (each within the scatter of the next); then compound 2.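

In this assay, the change from 4-chlorophenyl to 3-hydroxyphenyl on the carbonyl carbon gives a 4.8-fold lower number from compound 2 to compound 3 (0.68 log units; beyond the scatter) and is beyond the scatter. Set against the 4-methoxyphenyl group at the same place, 3-hydroxyphenyl gives a 1.6-fold lower number from compound 1 to compound 3 (0.20 log units; within the scatter) and stays within the scatter, so these two groups cannot be told apart in this assay. Of the three groups, therefore, only 4-chlorophenyl stands apart, on the weaker side and beyond the scatter of both others, while a hydrogen-bond donor on the entering group brings no separation from 4-methoxyphenyl.

On these data alone, it remains open whether a 4-hydroxyphenyl, 3-aminophenyl or 3-carboxyphenyl group at this place would match the 3-hydroxyphenyl result. No evidence is available to explain why the 4-chlorophenyl group stands apart.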